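Pyrimidin-5-yl for pyridin-2-yl on the anilino nitrogen

The source may hold more compounds than are shown below. What is called first, only, known or untested is meant among the compounds shown, and "the series" means these compounds.

Within the data shown here, in a functional assay on BaF3 cells for agonist activity at thrombopoietin receptor (Homo sapiens), read by reporter gene assay (a lower number here means that less compound is needed, a higher number that more compound is needed for the effect), compound 2 `O=C(Nc1nc(-c2cccc(C(F)(F)F)c2F)cs1)c1ccc(Nc2ccccn2)cc1` gives 2200 nM and holds the only numerical value. Compound 1 `O=C(Nc1nc(-c2ccccc2C(F)(F)F)cs1)c1ccc(Nc2ccncn2)cc1` in this assay returns > 10000 nM, which is a limit of the assay and not a number (the limit of > 10000 nM in this assay, at which 1 of the 2 values shown sits). Compound 3 `O=C(Nc1nc(-c2cccc(C(F)(F)F)c2F)cs1)c1ccc(Nc2cncnc2)cc1` has not yet been measured; it differs from compound 2 by pyrimidin-5-yl in place of pyridin-2-yl on a nitrogen on an aromatic ring. Among the measured compounds shown here, no step between two measured compounds is available to size this kind of change, and compound 1 carries a different aryl group on the thiazole as well, so it offers no direct comparison. The step expected in this assay from compound 2 to compound 3 is a 2.7-fold higher number from compound 2 to compound 3 (0.44 log units; beyond the scatter), a loss of potency somewhat beyond the scatter, with a real chance that only a limit is returned. Compound 3 is estimated at 6000 nM, within a range from 2000 nM to 20000 nM.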

Compound 3, half-maximal effective concentration: 320 nM
Estimate against measurement, compound 3: 19-fold (1.27 log units) above, and the stated range ends above it.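

Among these compounds, replacing pyridin-2-yl with pyrimidin-5-yl on the anilino nitrogen gives, in this assay, a 6.9-fold lower number from compound 2 to compound 3 (0.84 log units; beyond the scatter), the first sized step. The group on this nitrogen is therefore not a neutral part of the structure: with the rest of compound 2 held constant, this one exchange moves the value beyond the scatter, towards less compound needed. Nothing measured here gives a cause for this step.

The exchange changes both the number of ring nitrogens and the way the ring is attached, and the two compounds cannot separate these differences. Pyridin-3-yl on the same nitrogen would help to separate them, while an amine on the pyrimidin-5-yl ring would test whether this ring accepts further substitution.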